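A few compounds are considered here, and "the series" means these few. Any claim that something is new, unique, unknown or untested is made for them only; others in the source may bear on it.

Measured in an ADME assay on microsomes from liver (Rattus norvegicus) for metabolic stability; a lower number here means that the compound disappears faster, a higher number that the compound lasts longer:
- compound 1 `CC(C)C(CC1C(=O)NC(=O)N1C)c1ccc(-c2ccc3cccc(F)c3c2)[nH]c1=O`: < 0.0667 h
- compound 2 `CCC(/C=C1\OC(=O)NC1=O)(CC)c1ccc(-c2ccc3cc(F)cc(F)c3c2)[nH]c1=O`: > 3 h
- compound 3 `O=C1NC(=O)/C(=C/C2(c3ccc(-c4ccc5cccc(F)c5c4)[nH]c3=O)CCCC2)O1`: > 3 h

All three values are limits of the assay and not exact numbers. Compound 1 stands at the limit of < 0.0667 h in this assay, at which 1 of the 3 values shown sits. This places it at the short-lived end of the set. Compound 2 and compound 3 both stand at the limit of > 3 h in this assay, at which 2 of the 3 values shown sit. They differ from compound 1 in more than one place, so their values say little about a single small change.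

The next compound to be measured is compound 4 `CC(C)C(c1ccc(-c2ccc3cccc(F)c3c2)[nH]c1=O)C1C(=O)NC(=O)N1C`. It keeps the core of compound 1, and the change is confined to one side chain: 3-methyl-2,5-dioxoimidazolidin-4-yl in place of (3-methyl-2,5-dioxoimidazolidin-4-yl)methyl on a saturated chain carbon bound to an aromatic carbon and a saturated chain carbon. In words, 3-methyl-2,5-dioxoimidazolidin-4-yl stands in place of (3-methyl-2,5-dioxoimidazolidin-4-yl)methyl on a saturated chain carbon bound to an aromatic carbon and a saturated chain carbon.

Among the measured compounds shown here, no measured pair in this set isolates a change of this kind. The expectation therefore starts from compound 1, which gives < 0.0667 h, a limit. Only a small step in this assay is expected, either slightly upward or none beyond the scatter. The expected step is an at least 1.4-fold higher number from compound 1 to compound 4 (0.17 log units; that floor lies within the scatter). For compound 4 the estimated half-life is 0.1 h, with an expected range of 0.04 h to 0.4 h.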

Compound 4, half-life: 0.263 h
Compound 4: middle estimate off by 2.6-fold (0.42 log units), on the low side; low and high end bracket the measured number.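

Setting 3-methyl-2,5-dioxoimidazolidin-4-yl in place of (3-methyl-2,5-dioxoimidazolidin-4-yl)methyl gives, in this assay, an at least 3.9-fold higher number from compound 1 to compound 4 (0.59 log units; beyond the scatter). This is the first pair shown that differs in one place only, and the difference is small: 9 heavy atoms leave, 8 enter, and the five-membered ring and its counts of donors and acceptors stay the same, so even this small shortening of the side chain is enough to move the half-life beyond the usual scatter. The step is a floor and not an exact size, because compound 1 is held at a limit and not at a number: the limit of < 0.0667 h in this assay, at which 1 of the 4 values shown sits.

Compound 2 and compound 3 differ from compound 4 in more than one place, so they cannot show whether the same shortening would raise the number on another side chain or core. Also open, going by these compounds, is what a longer chain carrying the same ring, or an amine or a carboxylic acid in place of that ring, would give in this assay.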